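The compounds below may be only part of what the source reports. "The series", "measured", "known", "first", "only" and "open" are said of these compounds alone.

Measured compounds: compound 1 `CCC[C@@H](OC(C)=O)C1=C(Br)C(=C(Br)Br)OC1=O` gives 2.1 ug/mL; compound 2 `CCCCC1=C(Br)C(OC)(C(Br)Br)OC1=O` gives 6.6 ug/mL.

In a functional assay on LNCaP cells (Homo sapiens) for cytotoxicity (a higher number here means that more compound is needed for the effect, a lower number that less compound is needed), compound 1 stands with the lowest of the two numbers, and compound 2 sits higher by a gap beyond the usual scatter. The two differ in several places at once, so no single change can be read from that gap. Compound 3 `CCC[C@@H](O)C1=C(Br)C(=C(Br)Br)OC1=O` has not yet been measured. It differs from compound 1 by hydrogen in place of acetyl on an oxygen on a saturated carbon. For the measured compounds named here, no measured pair shares this change, so the expected step is small, within the scatter or slightly toward a higher number. Compound 3 is therefore expected to give 3 ug/mL, in the range 1 ug/mL to 9 ug/mL, and that estimate means a step of a 1.4-fold higher number from compound 1 to compound 3 (0.15 log units; within the scatter).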

Compound 3, concentration for half-maximal effect: 6.7 ug/mL
Beside the measured number, compound 3's estimate is 2.2-fold (0.35 log units) below it, and the stated range covers the measured number.
By their numbers in this assay, from the lowest: compound 1; then compounds 2 and 3 (each within the scatter of the next).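

In this assay, the change from acetoxy to hydroxy on the saturated carbon gives a 3.2-fold higher number from compound 1 to compound 3 (0.50 log units; beyond the scatter) in this first comparison of compounds that differ in one place. Losing the acetyl therefore means that more compound is needed for the effect, so the group on this oxygen affects the result. No measurement shown explains this step.

Going by these compounds, it remains open whether a benzoyl group on the same oxygen would give a number closer to that of compound 1. An amine in place of the hydroxy group is equally untested among the compounds shown.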